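Methoxy removal on the aryl hydrazone of a tetrazole series

A few compounds are considered here, and "the series" means these few. Any claim that something is new, unique, unknown or untested is made for them only; others in the source may bear on it.

Compound 1 `COc1ccc(/C=N/NC(=O)CSc2nnnn2-c2cccc3ccccc23)cc1`, compound 2 `COc1ccc(/C=N/NC(=O)CSc2nnnn2-c2cccc3ccccc23)cc1OC` and compound 3 `COc1ccc(O)c(/C=N/NC(=O)CSc2nnnn2-c2cccc3ccccc23)c1` share one core and differ only in the aryl group carried on the hydrazone carbon. In an ADME assay on MT4 cells (Homo sapiens) for cytotoxicity, read by MTT assay (a higher number here means that more compound is tolerated, a lower number that less compound is tolerated), compound 2 gives 191000 nM and compound 3 gives 4510 nM. For compound 1 only a limit is reported in this assay, namely > 298000 nM, which is the limit of > 298000 nM in this assay, at which 1 of the 3 values shown sits. The change hydrogen in place of methoxy on an aromatic carbon brings an at least 1.5-fold higher number from compound 2 to compound 1 (0.19 log units; that floor lies within the scatter). The two cores differ by 2-hydroxy-5-methoxyphenyl in place of 3,4-dimethoxyphenyl on a carbon with a double bond to nitrogen, and this brings a 42-fold lower number from compound 2 to compound 3 (1.63 log units; beyond the scatter); against the limit of compound 1 the corresponding step reads an at least 66-fold lower number from compound 1 to compound 3 (1.82 log units; beyond the scatter).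

Compound 4 `O=C(CSc1nnnn1-c1cccc2ccccc12)N/N=C/c1ccccc1O` is not yet measured. It differs from compound 3 by hydrogen in place of methoxy on an aromatic carbon. This is the same kind of change as from compound 2 to compound 1, but the place is not the same: there the aromatic carbon was ortho to a methoxy group and meta to a large group, here it is meta to a large group and para to a hydroxy group. Within this series the hydroxy-bearing aryl of compound 3 sits far lower than the other two, and there is no measured pair showing how a methoxy removal behaves next to that hydroxy. The expected step is a 1.8-fold higher number from compound 3 to compound 4 (0.25 log units; within the scatter). It rests on an at least 1.5-fold higher number from compound 2 to compound 1 (0.19 log units; that floor lies within the scatter) and on the value that compound 3 gives, 4510 nM. Compound 4 is therefore estimated at 8000 nM, with an expected span from 2000 nM to 40000 nM.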

Compound 4, half-maximal cytotoxic concentration: 4850 nM
Compound 4: middle estimate off by 1.6-fold (0.22 log units), on the high side, within the range that was stated.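

In this assay, hydrogen in place of methoxy on the hydroxy-bearing aryl gives a 1.1-fold higher number from compound 3 to compound 4 (0.03 log units; within the scatter), while the gaps to the aryl groups without hydroxy remain large, with a 39-fold lower number from compound 2 to compound 4 (1.60 log units; beyond the scatter) and an at least 61-fold lower number from compound 1 to compound 4 (1.78 log units; beyond the scatter). Read on two cores, the change gives no sign that its step depends on the core, but this does not show that the step carries over unchanged from one core to the other: the same change on two cores in this assay, an at least 1.5-fold higher number (0.19 log units; that floor lies within the scatter) from compound 2 to compound 1 and a 1.1-fold higher number (0.03 log units; within the scatter) from compound 3 to compound 4; the limit leaves it open whether they differ Compound 1 stands at a limit and not at a number, so the step that ends there is only a floor, and its true size on that core remains unknown: the limit of > 298000 nM in this assay, at which 1 of the 4 values shown sits.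

Open is whether the low numbers of compound 3 and compound 4 belong to the hydroxy group itself or to the 2-hydroxyphenyl arrangement as a whole, since the compounds shown hold that group only in this one place. Also open, as far as these compounds go, is how an amine or a carboxylic acid in place of that hydroxy group would read in this assay, and whether methoxy removal would give a similar step on such an aryl.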